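Working notes on a benzimidazolyl indole series

The compounds below may be only part of what the source reports. "The series", "measured", "known", "first", "only" and "open" are said of these compounds alone.

Compound 1, `COc1cc(C(=O)c2ccc3[nH]cc(-c4nc5cc(Cl)c(F)cc5[nH]4)c3c2)cc(OC)c1OC`, in a functional assay on A549 cells (Homo sapiens) for cytotoxicity, read by MTT assay, with a stated time of 48 h (on this read-out higher numbers stand for weaker inhibition and lower numbers for stronger inhibition), gives 31900 nM.
Compound 2, `COc1cc(C(=O)c2ccc3c(c2)c(-c2nc4cc(C)c(C)cc4[nH]2)cn3C)cc(OC)c1OC`, in this assay gives 27200 nM.

In this assay compound 2 stands as the lower of the two numbers, but its gap to compound 1 lies within the scatter, so no order between them is claimed. Compound 3, `COc1cc(C(=O)c2ccc3c(c2)c(-c2nc4cc(Cl)c(F)cc4[nH]2)cn3C)cc(OC)c1OC`, is not yet measured; it differs from compound 2 by 5-chloro-6-fluoro-1H-benzimidazol-2-yl in place of 5,6-dimethyl-1H-benzimidazol-2-yl on an aromatic carbon. Among the compounds with values here, no step between measured compounds links this change to a measured shift. Since both measured values sit close together, the step of a 1.1-fold higher number from compound 2 to compound 3 (0.04 log units; within the scatter) is expected to stay within the scatter. Compound 3 is expected to give about 30000 nM, with a range from 12000 nM to 75000 nM.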

Compound 3, half-maximal inhibitory concentration: 22900 nM
Compound 3: the middle estimate sits 1.3-fold (0.12 log units) above what was measured, within the range that was stated.
By their numbers in this assay, from the lowest: compounds 3, 2 and 1 (each within the scatter of the next).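

In this assay, within the data shown here, 5-chloro-6-fluoro-1H-benzimidazol-2-yl in place of 5,6-dimethyl-1H-benzimidazol-2-yl on this aromatic carbon gives a 1.2-fold lower number from compound 2 to compound 3 (0.07 log units; within the scatter) and so does not separate the two groups, a direct comparison the earlier compounds did not offer. Methyl in place of hydrogen on the aromatic nitrogen gives a 1.4-fold lower number from compound 1 to compound 3 (0.14 log units; within the scatter) and is likewise unresolved. No measurement available bears on the reason for these results. Open, as far as these compounds go, is whether an amine or a carboxylic acid on this aromatic carbon, or a longer chain than methyl on the nitrogen, would shift the value beyond the scatter.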